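The source may report more compounds than this note shows. Statements on the series, on what has been measured and on what is new or still open speak of the compounds shown alone.

Compound 1 `Cc1cnn(C(=O)N2CCCN(Cc3ccc(OCc4ccccc4)cc3)CC2)c1` gives 560 nM in an assay on membranes from brain for binding affinity to Fatty-acid amide hydrolase 1 (Mus musculus), read by fluorescence, with stated times of 1 h and 30 min; on this read-out higher numbers stand for weaker inhibition and lower numbers for stronger inhibition.
Compound 2 `O=C(N1CCCN(Cc2ccc(OCc3ccccc3)cc2)CC1)n1cccn1` gives 450 nM in this assay.
Compound 3 `Cc1cnn(C(=O)N2CCN(C(c3ccc(OCc4ccccc4)cc3)c3ccc(OCc4ccccc4)cc3)CC2)c1` gives > 100000 nM in this assay, which is a limit of the assay and not a number.

Compound 1 and compound 2 share a core and differ in one place, (hydrogen in place of methyl on an aromatic carbon). In this assay this change gives a 1.2-fold lower number from compound 1 to compound 2 (0.09 log units; within the scatter), so the two values show no difference that can be told from repeat measurement. Compound 3 carries a different core; how its core differs from that of compound 1 is not broken down here. For compound 3 only a limit is known, (the limit of > 100000 nM in this assay, at which 1 of the 3 values shown sits).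

Compound 4 `O=C(N1CCN(C(c2ccc(OCc3ccccc3)cc2)c2ccc(OCc3ccccc3)cc2)CC1)n1cccn1` has not yet been measured in this assay. It stands to compound 3 as compound 2 stands to compound 1: the change is hydrogen in place of methyl on an aromatic carbon, made at a place that is described in the same words as the change from compound 1 to compound 2, so it is the same change. On the measured pair this change moved the value by a 1.2-fold lower number from compound 1 to compound 2 (0.09 log units; within the scatter), a step within the scatter, and that is the only measured instance of it among these compounds. Compound 4 is therefore expected to stay close to compound 3, with an expected step of a number no higher from compound 3 to compound 4 (the limit leaves the size open). Since compound 3 gives only a limit, the most likely outcome for compound 4 is that the assay again reports a limit; as a number, compound 4 is estimated at 100000 nM, with a range from 30000 nM to 300000 nM.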

Compound 4, half-maximal inhibitory concentration: > 100000 nM
Compound 4 gave a limit, no number; the forecaster's own chance of this, stated with the estimate: 80%; the middle value lies on the limit itself.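

In this assay compound 4 gives > 100000 nM, which is a limit of the assay and not a number. Compound 3 also gives only a limit, so no step between compound 3 and compound 4 can be read: the limit of > 100000 nM in this assay, at which 2 of the 4 values shown sit.

The compounds shown leave open whether going from 4-methyl-1H-pyrazol-1-yl to 1H-pyrazol-1-yl changes the value at all on the core of compound 3.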